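A Reversed Ring Stereocentre on the Amide Side Chain

The compounds below may be only part of what the source reports. "The series", "measured", "known", "first", "only" and "open" are said of these compounds alone.

Compound 1, `CCC(=O)N1CC2CC(C1)N2`, gives 98% in an assay on SH-EP1 cells for agonist activity at Neuronal acetylcholine receptor; alpha4/beta2 (Homo sapiens), read by FLIPR and calcium flux; a higher number here means a larger maximal response, a lower number a smaller maximal response.
Compound 2, `C[C@H]1C[C@H]1C(=O)N1CC2CC(C1)N2`, gives 87% in this assay.

Within the data shown here, of these two numbers compound 2 holds the lower one; its nearest neighbour is compound 1, and the only measured step runs a number 11 percentage points lower from compound 1 to compound 2 (beyond the scatter), brought about by 2-methylcyclopropyl in place of ethyl on a carbonyl carbon. Compound 3, `C[C@H]1C[C@@H]1C(=O)N1CC2CC(C1)N2`, has not been measured. It differs from compound 2 by the two compounds have the same atoms and bonds; at least one stereo element is drawn with a configuration in one of them and without one in the other: 1 of 4 stereo elements differ; a stereocentre at a saturated ring carbon is drawn R in compound 2 and S in compound 3.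

Among the measured compounds shown here, no measured step involves a change of configuration alone, so nothing among the measured compounds speaks directly to this step. For the measured compounds named here, the only step on record, from a different change, was modest. Compound 3 is therefore expected to land near compound 2 in this assay, with a step estimated as a number 2 percentage points lower from compound 2 to compound 3 (within the scatter), not beyond the scatter. The estimate for compound 3 is 85%, with a range from 68% to 100%.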

Compound 3, largest response reached (Emax), in percent of the reference or control that the assay uses: 67%
Beside the measured number, compound 3's estimate is 18 percentage points above it, outside the stated range (below it).
By their numbers in this assay, from the lowest: compound 3; then compound 2; then compound 1.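

In this assay, among these compounds, the configuration at this saturated ring carbon matters on its own, a point the earlier compounds could not show: the step is (a number 20 percentage points lower from compound 2 to compound 3 (beyond the scatter)). Replacing ethyl with 2-methylcyclopropyl therefore has no single cost, since the step depends on how the ring is drawn: (a number 11 percentage points lower from compound 1 to compound 2 (beyond the scatter)) for one form and (a number 31 percentage points lower from compound 1 to compound 3 (beyond the scatter)) for the other. The two compounds have the same atoms and bonds, and the only difference on record between them is this one: the fact that one of compounds 2 and 3 is drawn with a defined configuration and the other without, at the place where they differ

The compounds shown leave open how the remaining stereo elements of the 2-methylcyclopropyl group bear on the response in this assay. They also leave open whether the same sensitivity to configuration would persist if a hydroxymethyl group or a longer chain took the place of the methyl on that ring.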